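The compounds below may be only part of what the source reports. "The series", "measured", "known", "first", "only" and "open" are said of these compounds alone.

Measured so far:
compound 1 `CC(C)C(NC(=O)c1ccc2ccccc2c1)C(=O)N1CCC(c2ccc(Cl)cc2)CC1`: 80 nM
compound 2 `Cc1ccccc1C(=O)NC(CC(C)C)C(=O)N1CCC(c2ccc(Cl)cc2)CC1`: 88 nM

Both were tested in an assay on THP-1 cells for displacement of a labelled ligand from C-C chemokine receptor type 1 (Homo sapiens); a lower number here means a stronger inhibitor, a higher number a weaker inhibitor. In this assay compound 1 gives 80 nM and compound 2 gives 88 nM. Compound 2 has the higher of the two numbers, but its gap to compound 1 is within the scatter, so the two compounds cannot be told apart on these data. Compound 3 `Cc1ccccc1C(=O)NC(C(=O)N1CCC(c2ccc(Cl)cc2)CC1)C(C)C` keeps the amide and the shared core of compound 2 and changes only the side chain: isopropyl in place of isobutyl on a saturated chain carbon bound to an amide-type nitrogen and a carbonyl carbon. Among the measured compounds shown here, no pair of measured compounds differs in this one place alone, so the size of the step cannot be read off from a measured pair. Compound 1, which carries the same isopropyl side chain with a different amide, gives 80 nM, so a compound with this side chain has already given a number in the same region. The step from compound 2 to compound 3 in this assay is therefore expected to be small, a 1.1-fold higher number from compound 2 to compound 3 (0.06 log units; within the scatter), and not beyond the scatter in either direction. Compound 3 is estimated to give 100 nM in this assay, with a range of 40 nM to 300 nM.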

Compound 3, half-maximal inhibitory concentration: 36 nM
The estimate for compound 3 lay 2.8-fold (0.44 log units) above the measured number; the measured number lies below the stated range.
By their numbers in this assay, from the lowest: compound 3; then compounds 1 and 2 (each within the scatter of the next).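

In this assay, the side chain on this saturated chain carbon bound to an amide-type nitrogen and a carbonyl carbon clearly matters: isopropyl in place of isobutyl gives a 2.4-fold lower number from compound 2 to compound 3 (0.39 log units; beyond the scatter), a modest step but beyond the scatter. With isopropyl held constant, 2-methylphenyl in place of naphthalen-2-yl on a carbonyl carbon gives a 2.2-fold lower number from compound 1 to compound 3 (0.35 log units; beyond the scatter), so this second place also moves the number, which compound 1 and compound 2 could not show, as they differ in both places. No measurement available here accounts for either step.

Only isobutyl and isopropyl are shown on this carbon, so it remains open how a methyl, a cyclohexyl or a chain bearing an amine would behave there. From the compounds shown here alone, it is also open whether the two steps would hold with other amide groups, such as a pyridine ring in place of 2-methylphenyl.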